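Chloro for Fluoro Across Two Related Cores

This account rests on a few compounds, and the source may have more. Where it says the series, first, only, none or still open, it means among the compounds named here.

Three compounds were measured in a functional assay (plasma) for inhibition, with Homo sapiens as the target; on this read-out lower numbers stand for stronger inhibition and higher numbers for weaker inhibition:

Compound 1 `O=C(O)CCC/C=C\C[C@@H]1[C@@H](NS(=O)(=O)c2ccc(F)cc2)CC[C@@H]1O`: 640 nM
Compound 2 `O=C(O)CCC/C=C\C[C@@H]1[C@@H](NS(=O)(=O)c2ccc(Cl)cc2)CC[C@@H]1O`: 190 nM
Compound 3 `O=C(O)CCC/C=C\C[C@H]1/C(=N/OCC2CCCCC2)CC[C@@H]1NS(=O)(=O)c1ccc(F)cc1`: 1800 nM

Compound 1 and compound 2 share a core and differ only by chloro in place of fluoro on an aromatic carbon, a change that brought a 3.4-fold lower number from compound 1 to compound 2 (0.53 log units; beyond the scatter). Compound 3 has a different core; the difference between the two cores is not broken down here. Compound 4 `O=C(O)CCC/C=C\C[C@H]1/C(=N/OCC2CCCCC2)CC[C@@H]1NS(=O)(=O)c1ccc(Cl)cc1` stands to compound 3 exactly as compound 2 stands to compound 1, differing by chloro in place of fluoro on an aromatic carbon. Among the compounds with values here, compound 4 is therefore expected to move by a 3.4-fold lower number from compound 3 to compound 4 (0.53 log units; beyond the scatter), a step of about the size seen in the first pair, because a 3.4-fold lower number from compound 1 to compound 2 (0.53 log units; beyond the scatter) is the only guide available for this change. On that basis compound 4 is estimated at 530 nM, most likely between 250 nM and 1200 nM.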

Compound 4, half-maximal inhibitory concentration: 1700 nM
Compound 4: middle estimate off by 3.2-fold (0.51 log units), on the low side, outside the stated range (above it).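

On the core of compound 3, the same swap of fluoro for chloro gives a 1.1-fold lower number from compound 3 to compound 4 (0.02 log units; within the scatter) in this assay, so on this core the two compounds cannot be told apart. The step seen on the first core therefore did not carry over to the second: the same change on two cores in this assay, a 3.4-fold lower number (0.53 log units; beyond the scatter) from compound 1 to compound 2 and a 1.1-fold lower number (0.02 log units; within the scatter) from compound 3 to compound 4, 3.2-fold (0.50 log units) apart, beyond the scatter of two such steps. This shows that a lower number with chloro on one core cannot be assumed on another in this series. Within the data shown here, there is only one pair per core, and the data do not show why the cores differ or which behaviour is more typical.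

From the compounds shown here alone, it remains open which part of the difference between the cores matters. Going by these compounds, it is also open whether 4-bromophenyl or 4-methoxyphenyl in the same place would separate the two cores as well.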